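Estimating a flexible pyrrolidine side chain against a piperidine anchor

A few compounds are considered here, and "the series" means these few. Any claim that something is new, unique, unknown or untested is made for them only; others in the source may bear on it.

All three measured compounds share the same decyl-substituted aryl and five-membered heteroaromatic core and differ only in the group hanging from that ring. Compound 1 `CCCCCCCCCCc1ccc(-c2noc(CC3CCNC3)n2)cc1` gives 44% in an assay on HeLa cells for inhibition of sphingosine-1-phosphate transporter SPNS2 (Mus musculus), read by LC-MS, tested at 2 uM; a higher number here means more inhibition at the concentration tested (going by the name of the read-out), a lower number less inhibition. Compound 2 `CCCCCCCCCCc1ccc(-c2noc(C3CCNCC3)n2)cc1` gives 66%, the highest of the three numbers; compound 1 lies a number 22 percentage points higher from compound 1 to compound 2 (beyond the scatter) behind it, and compound 3 `CCCCCCCCCCc1ccc(-c2noc([C@@H](N)CCCN)n2)cc1`, which gives 40%, is the furthest away, as the step of a number 26 percentage points lower from compound 2 to compound 3 (beyond the scatter) shows. Between compound 1 and compound 3 the step of a number 4 percentage points lower from compound 1 to compound 3 (within the scatter) is within the scatter.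

Compound 4 `CCCCCCCCCCc1ccc(-c2noc(CC(O)CN3CCCC3)n2)cc1` has not yet been measured. Its change from compound 2 is 2-hydroxy-3-(pyrrolidin-1-yl)propyl in place of piperidin-4-yl on an aromatic carbon.

Within the data shown here, two measured steps bear on it. Both the step of a number 22 percentage points higher from compound 1 to compound 2 (beyond the scatter) and the step of a number 26 percentage points lower from compound 2 to compound 3 (beyond the scatter) show that the piperidin-4-yl group sits at the top, and every departure from it, whether to a shorter ring-bearing chain or to an open diamine, lost a modest amount. The new group is again a chain rather than the ring itself, so a modest loss is expected: a number 26 percentage points lower from compound 2 to compound 4 (beyond the scatter). Compound 4 is therefore estimated at 40%, with a range from 20% to 60%.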

Compound 4, a percentage reported as inhibition, at one concentration (the size of the read-out at that concentration, not a potency): 21%
The estimate for compound 4 lay 19 percentage points above the measured number; the range from low to high includes it.
By their numbers in this assay, from the lowest: compound 4; then compounds 3 and 1 (each within the scatter of the next); then compound 2.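

The 2-hydroxy-3-(pyrrolidin-1-yl)propyl group gives the largest step seen at this position in this assay, a number 45 percentage points lower from compound 2 to compound 4 (beyond the scatter), and it also falls clearly short of both other chains, with a number 19 percentage points lower from compound 3 to compound 4 (beyond the scatter) and a number 23 percentage points lower from compound 1 to compound 4 (beyond the scatter). Departures from piperidin-4-yl therefore do not settle at one level: compound 1 and compound 3 lie within the scatter of each other, while compound 4 stands apart from both, so the number depends on which chain replaces the ring and not only on the ring being gone. The entering group brings in a hydroxyl and a pyrrolidine together, so the step cannot be divided between them, and nothing available accounts for it in measured terms.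

On these data alone, whether the fall belongs to the hydroxyl or to the pyrrolidine at the end of the chain stays open, and a plain 3-(pyrrolidin-1-yl)propyl group would separate the two. Also open, as far as these compounds go, is whether any group at this position can exceed compound 2, for instance an azetidin-3-yl or a piperazin-1-yl group.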